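Aryl selenocyanate and diselenide carbamates: cytotoxicity notes

The source may hold more compounds than are shown below. What is called first, only, known or untested is meant among the compounds shown, and "the series" means these compounds.

Measured compounds:
compound 1, `COc1ccc(OC(=O)Nc2ccc([Se]C#N)cc2)cc1`: 4500 nM
compound 2, `CC(C)COC(=O)Nc1ccc([Se][Se]c2ccc(NC(=O)OCC(C)C)cc2)cc1`: 5500 nM
compound 3, `CCCOC(=O)Nc1ccc([Se]C#N)cc1`: 3700 nM

All three compounds were run in an ADME assay on 184B5 cells (Homo sapiens) for cytotoxicity, read by MTT assay, with a stated time of 72 h; a higher number here means a weaker inhibitor of growth, a lower number a stronger inhibitor of growth. Compound 1 gives 4500 nM, compound 2 gives 5500 nM and compound 3 gives 3700 nM. The number for compound 3 is the smallest of the three, but its gap to compound 1 and its gap to compound 2 both lie within the usual scatter of this assay, so the three compounds are not separated by these data. For the measured compounds named here, no pair among the measured compounds differs in a single place, so no measured step exists against which a small change can be calibrated.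

Compound 4, `CCCCOC(=O)Nc1ccc([Se]C#N)cc1`, is not yet measured. It differs from compound 3 by methyl in place of hydrogen on a saturated chain carbon, three bonds along the chain from an oxygen next to a carbonyl group. With no measured step of this kind in the series, the expectation for this assay is a change of no more than the scatter, in no preferred direction. The step from compound 3 to compound 4 is therefore expected to be a 1.1-fold lower number from compound 3 to compound 4 (0.02 log units; within the scatter). Compound 4 is estimated at 3500 nM, with a range from 1800 nM to 7000 nM.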

Compound 4, concentration for 50% growth inhibition: 5300 nM
Estimate against measurement, compound 4: 1.5-fold (0.18 log units) below, within the range that was stated.
By their numbers in this assay, from the lowest: compounds 3, 1, 4 and 2 (each within the scatter of the next).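

Compound 4 gives the series its first measured single-place step: methyl in place of hydrogen on a saturated chain carbon, three bonds along the chain from an oxygen next to a carbonyl group, reads in this assay as a 1.4-fold higher number from compound 3 to compound 4 (0.16 log units; within the scatter) and does not separate the two compounds. For the compounds shown here, at this position, then, going from propyl to butyl leaves growth inhibition unresolved within the scatter, which is the first direct measure of how this position responds to a change. No data on any property of the chain accompany this step, so nothing explains the result.

Going by these compounds, whether a much longer chain, such as decyl, or a phenyl group at this position would move the number beyond the scatter stays open. Equally open, on these data alone, is how a selenocyanate and a diselenide compare when they carry the same chain.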